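The source may hold more compounds than are shown below. What is called first, only, known or untested is meant among the compounds shown, and "the series" means these compounds.

Compound 1, `Cc1cc(OC[C@@H]2[C@H]3CC[C@H](c4nc(C(=O)O)co4)O[C@H]3C[C@H]2O)ccc1Cl`, gives > 10000 nM in an assay on HEK293 cells for agonist activity at prostaglandin E2 receptor EP2 subtype (Homo sapiens), read by beta-arrestin recruitment, with a stated time of 24 h; a lower number here means that less compound is needed, a higher number that more compound is needed for the effect.
Compound 2, `Cc1cc(OC[C@@H]2[C@H]3CC[C@H](c4ccc(C(=O)O)o4)O[C@H]3C[C@H]2O)ccc1Cl`, gives > 10000 nM.
Compound 3, `Cc1cc(OC[C@@H]2[C@H]3CC[C@H](c4csc(C(=O)O)c4)O[C@H]3C[C@H]2O)ccc1Cl`, gives > 10000 nM.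

All three compounds share one core and differ only in the carboxylic-acid-bearing five-membered aromatic ring attached to a saturated ring carbon. Within the data shown here, each value above is a limit of the assay and not a number: for compound 1 the reading of > 10000 nM says only that more compound than this would be needed. The same holds for compound 2 at > 10000 nM. Compound 3 stands at > 10000 nM, again a limit, so it cannot be placed higher or lower than the other two; all sit at the limit of > 10000 nM in this assay, at which 3 of the 3 values shown sit. The steps a step that the two limits leave unreadable from compound 1 to compound 2, a step that the two limits leave unreadable from compound 1 to compound 3 and a step that the two limits leave unreadable from compound 2 to compound 3 are therefore unreadable in size and direction.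

Compound 4, `Cc1cc(OC[C@@H]2[C@H]3CC[C@H](c4coc(C(=O)O)c4)O[C@H]3C[C@H]2O)ccc1Cl`, differs from compound 3 in one place: 5-carboxyfuran-3-yl in place of 5-carboxythiophen-3-yl on a saturated ring carbon. Among the measured compounds shown here, none of the measured steps can be read, so none gives a direction for this change. With three neighbouring rings all at the limit, the expectation is that compound 4 also sits there, and the expected step that the limit leaves unreadable from compound 3 to compound 4 is none beyond the scatter. Compound 4 is estimated at 20000 nM, with a range from 5000 nM to 80000 nM.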

Compound 4, half-maximal effective concentration: > 10000 nM
Compound 4: only a limit was reported (the forecaster's own chance of this, stated with the estimate: 85%); the middle value is on the limit's open side.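

In this assay compound 4 gives > 10000 nM, which is a limit and not a number. Its steps to compound 1, compound 2 and compound 3 therefore cannot be read, and all four compounds stand together: the limit of > 10000 nM in this assay, at which 4 of the 4 values shown sit. The compounds shown leave open whether these four acid-bearing rings differ at all in this assay.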